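A few compounds are considered here, and "the series" means these few. Any claim that something is new, unique, unknown or untested is made for them only; others in the source may bear on it.

Measured so far in this study:

compound 1 `O=C1N(CCCCCOc2ccc(Br)cc2)CCN1c1ccncc1` — > 25000 nM
compound 2 `CSc1ccc(OCCCCCCN2CCN(c3ccncc3)C2=O)cc1` — > 25000 nM

Of the compounds shown here, two have been measured in a functional assay on cells (Homo sapiens) for cytotoxicity; a lower number here means that less compound is tolerated, a higher number that more compound is tolerated. Compound 1 gives only a limit there, > 25000 nM. Compound 2 likewise gives only a limit, > 25000 nM. Within the data shown here, compound 1 therefore stands at the limit of > 25000 nM in this assay, at which 2 of the 2 values shown sit, so no number sits below or above it, and no step between measured compounds can be drawn from these two results.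

Compound 3 `O=C1N(CCCCCOc2ccc(-c3cccs3)cc2)CCN1c1ccncc1` has not yet been measured. It differs from compound 1 in a single place: thiophen-2-yl in place of bromo on an aromatic carbon. Because both measured values sit at the limit of > 25000 nM in this assay, at which 2 of the 2 values shown sit, there is nothing in the data to show how far a change at that aromatic carbon moves the read-out in this assay. The step is therefore expected to be small, with no direction beyond the usual scatter, and the most likely outcome for compound 3 is that the assay again reports only a limit. Compound 3 is estimated at 25000 nM, within a range of 8000 nM to 60000 nM. The expected step is a number no higher from compound 1 to compound 3 (the limit leaves the size open).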

Compound 3, half-maximal cytotoxic concentration: > 25000 nM
Compound 3 gave a limit, no number (the forecaster's own chance of this, stated with the estimate: 70%); the middle value lies on the limit itself.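

In this assay compound 3 gives only a limit, > 25000 nM. Among these compounds, compound 1 also gives only a limit, so no step from compound 1 to compound 3 can be read: the limit of > 25000 nM in this assay, at which 3 of the 3 values shown sit. The compounds shown leave open at what concentration any of them becomes cytotoxic, and whether thiophen-2-yl in place of bromo changes that concentration at all.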